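Cytotoxicity limits and an added amino group

This account rests on a few compounds, and the source may have more. Where it says the series, first, only, none or still open, it means among the compounds named here.

Within the data shown here, compound 1 (`Nc1nc(O)c2ncn([C@@H]3S[C@H](CO)[C@H]3CO)c2n1`) and compound 2 (`OC[C@H]1[C@H](CO)S[C@@H]1n1cnc2c(O)ncnc21`) are the two measured members. In a functional assay on Vero cells (Chlorocebus sabaeus) for cytotoxicity (on this read-out lower numbers stand for stronger inhibition and higher numbers for weaker inhibition), compound 1 gives > 100000 nM, which is a limit and not a number. In this assay compound 2 gives > 100000 nM, also a limit. Among the measured compounds shown here, compound 2 therefore has no numerical standing, and the only other value shown is a limit too.

Compound 3 (`Nc1nc(O)c2ncn([C@H]3S[C@@H](CO)[C@@H]3CO)c2n1`) remains to be measured. Its difference from compound 2 is amino in place of hydrogen on an aromatic carbon, between two ring nitrogen atoms. For the measured compounds named here, no measured step shows the size of such a change. No change beyond the scatter is expected in this assay because of the limit of > 100000 nM in this assay, at which 2 of the 2 values shown sit. The expected step that the limit leaves unreadable from compound 2 to compound 3 is accordingly estimated to stay within the scatter. For compound 3 the estimated value is 120000 nM, with an expected range from 60000 nM to 300000 nM.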

Compound 3, half-maximal inhibitory concentration: > 100000 nM
Compound 3: a limit, no number; the forecaster's own chance of this, stated with the estimate: 90%; the middle value is on the limit's open side.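

In this assay compound 3 gives > 100000 nM, again a limit and not a number. The steps to compound 3 from compound 2 and from compound 1 cannot be read. Left open is whether the added amino group or the inverted stereocentres alter the result in this assay at all.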